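Aryl swap on the acrylamide core: outlook for compound 3

A few compounds are considered here, and "the series" means these few. Any claim that something is new, unique, unknown or untested is made for them only; others in the source may bear on it.

Compound 1 `N#C/C(=C\c1ccc[nH]1)C(=O)NCc1ccc(Cl)c(Cl)c1` was tested in a functional assay on NCI-H460 cells (Homo sapiens) for inhibition, read by MTT assay, with a stated time of 72 h; a higher number here means a weaker inhibitor of growth, a lower number a stronger inhibitor of growth. In this assay compound 1 gives only a limit of the assay, > 50000 nM, so it sits at the weak end of the two numbers shown, as in the limit of > 50000 nM in this assay, at which 1 of the 2 values shown sits. Compound 2 `COc1ccc(CNC(=O)/C(C#N)=C/c2ccc(Cl)o2)cc1` differs from compound 1 in more than one place; in this assay compound 2 gives 15000 nM. Among the measured compounds shown here, no step between measured compounds is known, so the size of any change must be estimated. Compound 3 `N#C/C(=C\c1ccc(Cl)cc1)C(=O)NCc1ccc(Cl)c(Cl)c1` is not yet measured and differs from compound 1 by 4-chlorophenyl in place of 1H-pyrrol-2-yl on a double-bonded chain carbon bound to a double-bonded chain carbon. Because compound 1 gives only the limit > 50000 nM in this assay, the direction toward stronger growth inhibition is expected for compound 3 but its size is uncertain, and the step from compound 1 to compound 3 is expected to be an at least 2.5-fold lower number from compound 1 to compound 3 (0.39 log units; beyond the scatter). Compound 3 is estimated at 20000 nM, with a range from 5000 nM to 60000 nM, and a limit remains possible.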

Compound 3, concentration for 50% growth inhibition: 33000 nM
Estimate against measurement, compound 3: 1.7-fold (0.22 log units) below, and the stated range covers the measured number.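

With the rest of the core of compound 1 held fixed, 4-chlorophenyl in place of 1H-pyrrol-2-yl on a double-bonded chain carbon bound to a double-bonded chain carbon gives, in this assay, an at least 1.5-fold lower number from compound 1 to compound 3 (0.18 log units; that floor lies within the scatter). Compound 3 gives a measured number at this position, 33000 nM, so a reading in this assay does not depend on the hydrogen-bond donor of 1H-pyrrol-2-yl. The true size of the step stays unknown, because compound 1 stands at a limit of the assay: the limit of > 50000 nM in this assay, at which 1 of the 3 values shown sits.

As far as these compounds go, whether the chlorine of 4-chlorophenyl contributes at all, as against a plain phenyl, stays open. Also open, from the compounds shown here alone, is how a dimethylamino group or a carboxylic acid on that ring would read in this assay.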